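Methoxy on the thiazole aryl in a thioether-linked series

The source may report more compounds than this note shows. Statements on the series, on what has been measured and on what is new or still open speak of the compounds shown alone.

Measured compounds:
compound 1 `COc1ccc(-c2nc(C)c(C(=O)CSc3nc(-c4ccc(Cl)cc4)c(C#N)c(=O)[nH]3)s2)cc1`: 92.7%
compound 2 `Cc1nc(-c2ccccc2)sc1C(=O)CSc1nc(-c2ccccc2)c(C#N)c(=O)[nH]1`: 87.5%

In a functional assay on U-87MG ATCC cells for antiproliferative activity against U-87 MG (Homo sapiens), read by MTT assay, with a stated time of 48 h, tested at 10 uM (a higher number here means a weaker effect of the compound at the concentration tested, a lower number a stronger effect), compound 2 gives 87.5%, the lower of the two numbers, while compound 1 gives 92.7%, a gap within the scatter. Compound 3 `COc1ccc(-c2nc(C)c(C(=O)CSc3nc(-c4ccccc4)c(C#N)c(=O)[nH]3)s2)cc1` is not yet measured. It differs from compound 2 by methoxy in place of hydrogen on an aromatic carbon, the methoxy sitting para to a large group on the six-membered carbon ring. With both measured compounds close together, no step beyond the scatter is expected for compound 3 in this assay, that is a number 2.5 percentage points higher from compound 2 to compound 3 (within the scatter). Compound 3 is estimated at 90%, within 80% to 98%.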

Compound 3, a percentage reported as activity, at one concentration (the size of the read-out at that concentration, not a potency): 90.9%
Compound 3: the middle estimate sits 0.9 percentage points below what was measured; measured number inside the range.
By their numbers in this assay, from the lowest: compounds 2, 3 and 1 (each within the scatter of the next).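

Phenyl to 4-methoxyphenyl gives a number 3.4 percentage points higher from compound 2 to compound 3 (within the scatter) in this assay, the first reading of this change on its own, with the methoxy para to a large group. Hydrogen in place of chloro on an aromatic carbon gives a number 1.8 percentage points lower from compound 1 to compound 3 (within the scatter), so neither single change separates its pair at this concentration. No supporting data bear on these results.

As far as these compounds go, whether an amine, a carboxylic acid or a longer chain in place of the methoxy would give a step beyond the scatter remains open. So does the effect of either change on a different core.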